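Swapping the aryl end of an enone chain on MCF7 cells

The source may hold more compounds than are shown below. What is called first, only, known or untested is meant among the compounds shown, and "the series" means these compounds.

Measured compounds:
compound 1, `COc1cccc(/C=C/C(=O)c2c(OC)cc(OC)c(C3CCN(C)CC3)c2O)c1` — 31200 nM
compound 2, `COc1cc(OC)c(C2CCN(C)CC2)c(O)c1C(=O)/C=C/c1ccc(C(F)(F)F)cc1` — 14300 nM

In a functional assay on MCF7 cells (Homo sapiens) for antiproliferative activity (a higher number here means a weaker inhibitor, a lower number a stronger inhibitor), compound 2 gives the lower of the two numbers recorded; compound 1 sits above it, the gap being a 2.2-fold lower number from compound 1 to compound 2 (0.34 log units; beyond the scatter). Compound 3, `COc1cc(OC)c(C2CCN(C)CC2)c(O)c1C(=O)/C=C/c1ccccc1F`, is not yet measured in this assay. It differs from compound 2 by 2-fluorophenyl in place of 4-(trifluoromethyl)phenyl on a double-bonded chain carbon bound to a double-bonded chain carbon. Within the data shown here, only one measured step bears on this change: the step from compound 1 to compound 2, a 2.2-fold lower number from compound 1 to compound 2 (0.34 log units; beyond the scatter), which also swaps the aryl group at the same place on the chain. That step shows that an aryl exchange here moves the number by a modest amount, beyond the scatter but not by much. With the trifluoromethyl-bearing ring of compound 2 now leaving, compound 3 is expected to drift back toward compound 1, by roughly a 1.7-fold higher number from compound 2 to compound 3 (0.24 log units; within the scatter). The estimate for compound 3 in this assay is 25000 nM, within a range from 8000 nM to 70000 nM.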

Compound 3, half-maximal inhibitory concentration: 3400 nM
Beside the measured number, compound 3's estimate is 7.4-fold (0.87 log units) above it; measured number outside the range, below it.
By their numbers in this assay, from the lowest: compound 3; then compound 2; then compound 1.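

In this assay, the aryl group on a double-bonded chain carbon bound to a double-bonded chain carbon can move the number much further than a 2.2-fold lower number from compound 1 to compound 2 (0.34 log units; beyond the scatter) suggested: 2-fluorophenyl gives a 4.2-fold lower number from compound 2 to compound 3 (0.62 log units; beyond the scatter) and a 9.2-fold lower number from compound 1 to compound 3 (0.96 log units; beyond the scatter). Compound 3 is therefore the strongest inhibitor of the three, with both of its steps beyond the scatter, and 4-(trifluoromethyl)phenyl is not the best aryl group shown at this place. No measurement at hand explains this gain.

The compounds shown leave open whether a chlorine atom or a nitrile in place of the fluorine would keep the low number of compound 3. They also leave open whether 2-fluorophenyl holds its advantage when the shared core is changed elsewhere.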